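From cyclohexylamino to hydroxy on a saturated ring carbon

This account rests on a few compounds, and the source may have more. Where it says the series, first, only, none or still open, it means among the compounds named here.

Compound 1 `CC1(C)Nc2c(ccc(C(=O)c3ccccc3)c2O)OC1NC1CCCCC1`: 120 uM
Compound 2 `CC(C)CNC1Oc2ccc(C(=O)c3ccccc3)c(O)c2NC1c1ccccc1`: 79 uM

In a functional assay on HT-22 cells (Mus musculus), read by LDH release (on this read-out lower numbers stand for higher toxicity in this test and higher numbers for lower toxicity in this test), compound 1 gives 120 uM and compound 2 gives 79 uM. These two values lie within the usual scatter of each other, so neither compound stands apart. Compound 3 `CC1(C)Nc2c(ccc(C(=O)c3ccccc3)c2O)OC1O` keeps the core of compound 1 but carries hydroxy in place of cyclohexylamino on a saturated ring carbon, next to the ring oxygen (hydroxy in place of cyclohexylamino on a saturated ring carbon). Within the data shown here, no two measured compounds differ in one place only, so the data give no direct guide to this change. A small move towards a higher number, meaning lower toxicity, is expected, and it may not exceed the scatter. The estimated step is a 1.3-fold higher number from compound 1 to compound 3 (0.12 log units; within the scatter). For compound 3, the expected value is 160 uM, with an estimated range from 70 uM to 360 uM.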

Compound 3, half-maximal toxic concentration: > 250 uM
Compound 3 was reported as a limit (the forecaster's own chance of this, stated with the estimate: 25%); middle value at least 1.5-fold (0.19 log units) from the limit.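

In this assay compound 3 gives > 250 uM, which is a limit of the assay and not a number. On this saturated ring carbon, next to the ring oxygen, hydroxy in place of cyclohexylamino gives an at least 2.0-fold higher number from compound 1 to compound 3 (0.31 log units; beyond the scatter), so this single change, which removes the carbon ring, goes with lower toxicity in this test. Only the lower bound of that step can be read: the limit of > 250 uM in this assay, at which 1 of the 3 values shown sits.

The compounds shown leave open whether the move follows the loss of the cyclohexyl ring or the arrival of the hydroxy group. A methoxy group or a small amine such as methylamino on the same carbon would separate the two, and would show how much of the step remains without the hydroxy group.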